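Removing One Chlorine from a Purine Cytotoxic Lead

This account rests on a few compounds, and the source may have more. Where it says the series, first, only, none or still open, it means among the compounds named here.

Two purine compounds have been tested in a functional assay on OVCAR-3 cells (Homo sapiens) for cytotoxicity, read by sulforhodamine B assay, with a stated time of 48 h; on this read-out lower numbers stand for higher toxicity in this test and higher numbers for lower toxicity in this test. Compound 1 `ClCc1ccc(Cn2cnc3c(Cl)ncnc32)cc1` gives 8910 nM. Compound 2 `ClCc1ccccc1Cn1cnc2c(Cl)nc(Cl)nc21` gives 1540 nM, the lower of the two numbers, so it is the more toxic of the pair, and its gap to compound 1 lies beyond the usual scatter. Compound 3 `ClCc1ccccc1Cn1cnc2c(Cl)ncnc21` has not yet been tested; it differs from compound 2 by hydrogen in place of chloro on an aromatic carbon. For the measured compounds named here, no measured pair shows this exact change, so only a modest loss of toxicity is expected, with a step of a 1.9-fold higher number from compound 2 to compound 3 (0.29 log units; within the scatter) in this assay. Compound 3 is therefore expected to give about 3000 nM, within a likely range from 1000 nM to 10000 nM.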

Compound 3, concentration lethal to 50% of the cells: 8910 nM
Compound 3: the middle estimate sits 3.0-fold (0.47 log units) below what was measured; the range from low to high includes it.
By their numbers in this assay, from the lowest: compound 2; then compounds 1 and 3 (each within the scatter of the next).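

In this assay, replacing the chloro on the aromatic carbon between two ring nitrogen atoms with hydrogen gives a 5.8-fold higher number from compound 2 to compound 3 (0.76 log units; beyond the scatter). For the compounds shown here, this is the first direct sign that this position matters for toxicity in this test, as the chloro goes with the lower number and a single atom accounts for the whole step. Nothing available explains why this swap has this size. The compounds shown leave open whether an amine or a methoxy group on this carbon would behave more like chloro or like hydrogen.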